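A few compounds are considered here, and "the series" means these few. Any claim that something is new, unique, unknown or untested is made for them only; others in the source may bear on it.

Compound 1 `CC(=O)Nc1cccc2c1CCCC2c1c[nH]cn1`: in an assay on isolated protein (Cricetulus griseus) for binding affinity to Alpha-1B adrenergic receptor (Mesocricetus auratus), read by radioligand binding (a higher number here means a weaker inhibitor, a lower number a stronger inhibitor), compound 1 gives < 10000 nM, which is a limit of the assay rather than a number.
Compound 2 `CCS(=O)(=O)Nc1cccc(C2CCNC2)c1`: in this assay compound 2 gives < 10000 nM, again only a limit.
Compound 3 `CS(=O)(=O)Nc1cccc2c1OCCC2c1c[nH]cn1`: in this assay compound 3 gives < 10000 nM, once more a limit.

Compound 2 therefore cannot be placed above or below the others; all three values sit at the limit of < 10000 nM in this assay, at which 3 of the 3 values shown sit, so no order among them is known. Going by the values given here, no step between two measured compounds is available either.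

Compound 4 `CCS(=O)(=O)Nc1cccc(Sc2c[nH]cn2)c1` differs from compound 2 in a single place: (1H-imidazol-4-yl)sulfanyl in place of pyrrolidin-3-yl on an aromatic carbon.

With only limits to rest on, the step that the limit leaves unreadable from compound 2 to compound 4 in this assay is expected to be modest and its direction is uncertain. Compound 4 is estimated to give about 2000 nM, within a range from 300 nM to 9000 nM.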

Compound 4, inhibition constant: < 10000 nM
Compound 4 gave a limit, no number; the forecaster's own chance of this, stated with the estimate: 40%; the middle value is on the limit's open side.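

In this assay, going by these compounds alone, compound 4 gives < 10000 nM, again only a limit, so no step from compound 2 to compound 4 can be read. How the compounds shown truly rank in strength stays open: the limit of < 10000 nM in this assay, at which 4 of the 4 values shown sit.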